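Replacing the methoxy of compound 1 with hydrogen

A few compounds are considered here, and "the series" means these few. Any claim that something is new, unique, unknown or untested is made for them only; others in the source may bear on it.

In a functional assay on NCI-H23 cells (Homo sapiens) for antiproliferative activity, read by MTT assay, with a stated time of 72 h (on this read-out higher numbers stand for weaker inhibition and lower numbers for stronger inhibition), compound 1 `C=CC(=O)Nc1cc(Nc2nccc(NC(=O)c3cccc(OC)c3)n2)c(OC)cc1N1CCN(C)CC1` gives 15900 nM, compound 2 `C=CC(=O)Nc1cc(Nc2nccc(NC(=O)c3ccc(C(F)(F)F)cc3)n2)c(OC)cc1N1CCN(C)CC1` gives 9200 nM and compound 3 `C=CC(=O)Nc1cc(Nc2nccc(NC(=O)c3cccc(OC)c3)n2)c(OC)cc1N(C)CCN(C)C` gives 11800 nM. Compound 1 therefore stands within the scatter of both neighbours. Compound 4 `C=CC(=O)Nc1cc(Nc2nccc(NC(=O)c3ccccc3)n2)c(OC)cc1N1CCN(C)CC1` carries one further change: hydrogen in place of methoxy on an aromatic carbon, which turns 3-methoxyphenyl into phenyl. The closest evidence changes the same aryl group, a 1.7-fold lower number from compound 1 to compound 2 (0.24 log units; within the scatter). The change at the other end of the molecule, a 1.3-fold lower number from compound 1 to compound 3 (0.13 log units; within the scatter), bears on it only loosely. Neither step leaves the scatter, so no shift beyond the scatter is expected in this assay. The expected step is a 1.3-fold lower number from compound 1 to compound 4 (0.10 log units; within the scatter). Compound 4 is estimated at 12500 nM, with an expected range of 6500 nM to 24000 nM.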

Compound 4, half-maximal inhibitory concentration: > 16000 nM
Compound 4 ended at the assay's limit; the forecaster's own chance of this, stated with the estimate: 5%; middle value at least 1.2-fold (0.10 log units) away from the limit.
By their numbers in this assay, from the lowest: compounds 2, 3 and 1 (each within the scatter of the next). At a limit, above all of these: compound 4.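

In this assay, removing the methoxy from the aryl ring yields no measurable gain, and compound 4 is read only as a limit: the limit of > 16000 nM in this assay, at which 1 of the 4 values shown sits. Going by these compounds alone, the reading for hydrogen in place of methoxy is a number no lower from compound 1 to compound 4 (the limit leaves the size open), so this position shows only that hydrogen gives a number no lower than methoxy. Against the trifluoromethyl analogue the reading is an at least 1.7-fold higher number from compound 2 to compound 4 (0.24 log units; that floor lies within the scatter), so no separation beyond the scatter is established.

On these data alone, it remains open how far compound 4 lies past the limit. As far as these compounds go, it is also open whether an amine or a carboxylic acid on this aromatic carbon would move the number beyond the scatter.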